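Ester swap and half-life in the series

The compounds below may be only part of what the source reports. "The series", "measured", "known", "first", "only" and "open" are said of these compounds alone.

Measured in an ADME assay (intestine, Homo sapiens) for pharmacokinetics, using microsomes; a lower number here means that the compound disappears faster, a higher number that the compound lasts longer:
- compound 1 `CCOc1cc(NC(=O)C2(NC(=O)c3ccc4c(C5CCCC5)c(-c5ncc(Cl)cn5)n(C)c4c3)CCC2)ccc1/C=C/C(=O)OCOP(=O)(O)O`: 0.467 h
- compound 2 `CCOc1cc(NC(=O)C2(NC(=O)c3ccc4c(C5CCCC5)c(-c5ncc(Cl)cn5)n(C)c4c3)CCC2)ccc1/C=C/C(=O)OCC(C)C`: > 5 h (a limit)

Going by the values given here, compound 1 gives the only exact number so far, 0.467 h. For compound 2 the reading is a limit: the limit of > 5 h in this assay, at which 1 of the 2 values shown sits. Compound 3 `CCOc1cc(NC(=O)C2(NC(=O)c3ccc4c(C5CCCC5)c(-c5ncc(Cl)cn5)n(C)c4c3)CCC2)ccc1/C=C/C(=O)OCC(Cl)(Cl)Cl` differs from compound 1 by a group of 4 heavy atoms (1 carbon, 3 chlorine; no ring) in place of a group of 5 heavy atoms (4 oxygen, 1 phosphorus; no ring), on a saturated chain carbon bound to an oxygen next to a carbonyl group; the group entering is trichloromethyl. Among the compounds with values here, the one measured step at this place is large: an at least 10-fold higher number from compound 1 to compound 2 (1.02 log units; beyond the scatter). A large rise in this assay is therefore expected for the new change, an estimated 8.6-fold higher number from compound 1 to compound 3 (0.93 log units; beyond the scatter). The expected value for compound 3 is 4 h, within an estimated range of 1.5 h to 8 h.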

Compound 3, half-life: > 5 h
Compound 3: no number, only a limit; the forecaster's own chance of this, stated with the estimate: 40%; middle value at least 1.2-fold (0.09 log units) away from the limit.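

A second entering group, trichloromethyl, now gives a large rise at this place in this assay: an at least 10-fold higher number from compound 1 to compound 3 (1.02 log units; beyond the scatter), so the rise is not confined to isopropyl. Compound 3 reads > 5 h, which is a limit and not a number. The step between compound 2 and compound 3 cannot be read, so isopropyl and trichloromethyl stay unranked: the limit of > 5 h in this assay, at which 2 of the 3 values shown sit.

Still open, from the compounds shown here alone, is the exact half-life of compound 2 and of compound 3. Also open, going by these compounds, is whether an amine, a carboxylic acid or a longer chain at this place would reach the same limit.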